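The compounds below may be only part of what the source reports. "The series", "measured", "known", "first", "only" and "open" are said of these compounds alone.

Measured compounds:
compound 1, `O=C(O)CCNC(=O)c1ccc(C(Oc2ccc(-n3cc(C(F)(F)F)cn3)cc2)C2CCCC2)cc1`: 22 mL/min/kg
compound 2, `CCCC(Oc1ccc(-n2cc(F)cn2)cc1)c1ccc(C(=O)NCCC(=O)O)cc1`: 12 mL/min/kg
compound 3, `CC(C)(C)C(Oc1ccc(-n2cc(C(F)(F)F)cn2)cc1)c1ccc(C(=O)NCCC(=O)O)cc1`: 31 mL/min/kg

In an ADME assay on microsomes from liver (Homo sapiens) for metabolic stability (a higher number here means faster removal of the compound, a lower number slower removal), compound 2 gives the lowest number of the three. Compound 1 lies nearest to compound 2, a gap within the scatter, so no order is read between these two. Compound 3 lies furthest from compound 2, a gap beyond the scatter, so compound 3 is cleared faster than compound 2. Going by the values given here, the one step measured between compounds that differ in one place, a 1.4-fold higher number from compound 1 to compound 3 (0.15 log units; within the scatter), concerns the saturated chain carbon bound to an aromatic carbon and an oxygen on an aromatic ring, not the five-membered aromatic ring with 2 nitrogen.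

Compound 4, `CCCC(Oc1ccc(-n2cc(OC)cn2)cc1)c1ccc(C(=O)NCCC(=O)O)cc1`, differs from compound 2 in one place: methoxy in place of fluoro on an aromatic carbon. Among the compounds with values here, no measured step touches this position. Compound 1 and compound 3 carry trifluoromethyl where compound 2 carries fluoro, but each also differs from compound 2 elsewhere, so their values cannot be tied to this ring alone. With nothing measured that bears on the change, the expectation for compound 4 is anchored on compound 2 with a slight lean towards a higher number and a wide range. The expected step is a 1.4-fold higher number from compound 2 to compound 4 (0.15 log units; within the scatter). Compound 4 is estimated at 17 mL/min/kg, within 8 mL/min/kg to 36 mL/min/kg.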

Compound 4, clearance: < 8 mL/min/kg
Compound 4 ended at the assay's limit; the forecaster's own chance of this, stated with the estimate: 5%; middle value at least 2.1-fold (0.32 log units) from the limit.
By their numbers in this assay, from the lowest: compounds 2, 1 and 3 (each within the scatter of the next, the first and the last beyond it). At a limit, below all of these: compound 4.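

In this assay, going by these compounds alone, the step of an at least 1.5-fold lower number from compound 2 to compound 4 (0.17 log units; that floor lies within the scatter) is the first reading at this aromatic carbon of the five-membered aromatic ring with 2 nitrogen in which nothing else changes; compound 1 and compound 3 carry trifluoromethyl there but also differ elsewhere. It shows that methoxy in place of fluoro at this position does not raise the number, although the floor of the step does not by itself establish a drop beyond the scatter. Compound 4 gives < 8 mL/min/kg, which is a limit of the assay and not a number, and the true size of the step cannot be read because that value marks only where the assay stops: the limit of < 8 mL/min/kg in this assay, at which 1 of the 4 values shown sits.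

Still open, from the compounds shown here alone, is whether the real gap from fluoro to methoxy lies beyond the scatter, which needs a value for compound 4 inside the range of this assay. Also open, going by these compounds, are whether an ethoxy group or an amine on the same carbon reads like methoxy, and whether methoxy gives a similar reading on the core of compound 1 or compound 3.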